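Benzyl for propyl: the step from compound 3 to compound 4

A few compounds are considered here, and "the series" means these few. Any claim that something is new, unique, unknown or untested is made for them only; others in the source may bear on it.

In an assay on HEK293 cells for inhibition of Steryl-sulfatase (Homo sapiens), tested at 1 uM (on this read-out lower numbers stand for a weaker effect and higher numbers for a stronger effect at the one concentration tested), the measured compounds give:
compound 1 `CN(C)CCN(CCN(C)C)c1ccc(C(=O)N2CCc3ccc(OS(N)(=O)=O)cc3C2)cc1`: 15.9%
compound 2 `NS(=O)(=O)Oc1ccc2c(c1)CN(C(=O)c1ccc(N(CCCO)Cc3ccccc3)cc1)CC2`: 64.3%
compound 3 `CCCN(CCC)c1ccc(C(=O)N2CCc3ccc(OS(N)(=O)=O)cc3C2)cc1`: 84.7%

Compound 3 stands highest of the three, with compound 2 nearest and compound 1 furthest, both beyond the scatter. Compound 4 `CCCN(Cc1ccccc1)c1ccc(C(=O)N2CCc3ccc(OS(N)(=O)=O)cc3C2)cc1` is still unmeasured; it differs from compound 3 by phenyl in place of ethyl on a saturated chain carbon bound to a nitrogen on an aromatic ring. For the measured compounds named here, the only single-change step on record, a number 68.8 percentage points higher from compound 1 to compound 3 (beyond the scatter), alters the group on the same nitrogen on an aromatic ring but not in the same way, so it gives no direct guide. Compound 2 also carries a benzyl on that nitrogen and sits below compound 3, although the two differ in two places. A modest fall is therefore expected for compound 4 in this assay, a number 14.7 percentage points lower from compound 3 to compound 4 (beyond the scatter), with little confidence. The estimate for compound 4 is 70%, between 45% and 90%.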

Compound 4, a percentage reported as inhibition, at one concentration (the size of the read-out at that concentration, not a potency): 94.3%
Estimate against measurement, compound 4: 24.3 percentage points below; measured number outside the range, above it.
By their numbers in this assay, from the lowest: compound 1; then compound 2; then compounds 3 and 4 (each within the scatter of the next).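

In this assay, phenyl in place of ethyl on this saturated chain carbon gives a number 9.6 percentage points higher from compound 3 to compound 4 (within the scatter), so this position accepts a benzyl as well as a propyl. With benzyl present, hydrogen in place of hydroxy on the other chain gives a number 30 percentage points higher from compound 2 to compound 4 (beyond the scatter), while benzyl(propyl)amino in place of bis(2-(dimethylamino)ethyl)amino gives a number 78.4 percentage points higher from compound 1 to compound 4 (beyond the scatter). No measurement at hand explains these steps.

On these data alone, whether butyl in place of propyl, or a carboxylic acid on the benzyl, would keep the read-out this high stays open. A single tested concentration also leaves open whether compound 3 and compound 4 would separate at other concentrations.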